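The source may report more compounds than this note shows. Statements on the series, on what has been measured and on what is new or still open speak of the compounds shown alone.

Measured so far:
Compound 1 `Cn1ccc(S(=O)(=O)Nc2cccc(NC(=O)COc3ccc4c(=O)ccoc4c3)c2)n1` gives 1350 nM in an assay on isolated protein for inhibition of Rho-associated protein kinase 2 (Homo sapiens), read by scintillation counting, radiometric assay and 33P incorporation, with a stated time of 40 min, in the presence of a further agent that is not named here; on this read-out lower numbers stand for stronger inhibition and higher numbers for weaker inhibition.
Compound 2 `CN(C)c1ccc(S(=O)(=O)Nc2cccc(NC(=O)COc3ccc4c(=O)ccoc4c3)c2)cc1` gives 263 nM in this assay.

Compound 2 therefore has the lowest number of the two, and the step of a 5.1-fold lower number from compound 1 to compound 2 (0.71 log units; beyond the scatter) lies beyond the scatter. Compound 3 `CC(C)(C)c1ccc(S(=O)(=O)Nc2cccc(NC(=O)COc3ccc4c(=O)ccoc4c3)c2)cc1` has not been measured. It differs from compound 2 by tert-butyl in place of dimethylamino on an aromatic carbon. Within the data shown here, the single measured step swapped the whole ring on the sulfonyl sulfur, so no measured step bears directly on this change. For compound 3 a shift in this assay of about a 1.7-fold higher number from compound 2 to compound 3 (0.23 log units; within the scatter) is expected, leaning toward a higher number, with an estimated value of 450 nM in a range of 150 nM to 1400 nM.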

Compound 3, half-maximal inhibitory concentration: 899 nM
Compound 3: the middle estimate sits 2.0-fold (0.30 log units) below what was measured; low and high end bracket the measured number.
By their numbers in this assay, from the lowest: compound 2; then compounds 3 and 1 (each within the scatter of the next).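

In this assay the group on this aromatic carbon clearly matters: tert-butyl in place of dimethylamino gives a 3.4-fold higher number from compound 2 to compound 3 (0.53 log units; beyond the scatter) and so loses most of what compound 2 had gained. Exchanging the ring on the sulfonyl sulfur gives a 1.5-fold lower number from compound 1 to compound 3 (0.18 log units; within the scatter) here, so the lower number goes with 4-(dimethylamino)phenyl, not with every six-membered aromatic ring. Nothing available here explains this difference. Still open, as far as these compounds go, is how a smaller amine such as methylamino, a methoxy group or a plain hydrogen would compare at this place. Such groups could show whether the nitrogen of dimethylamino goes with the lower number.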